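Cytotoxicity after the 4-acetamidophenoxy group leaves

A few compounds are considered here, and "the series" means these few. Any claim that something is new, unique, unknown or untested is made for them only; others in the source may bear on it.

In an ADME assay on THLE-2 cells (Homo sapiens) for cytotoxicity, read by luminescence, with a stated time of 72 h (on this read-out lower numbers stand for higher toxicity in this test and higher numbers for lower toxicity in this test), compound 1 `Nc1ccccc1NC(=O)C1(S(=O)(=O)c2ccc(Oc3ccc(OC(F)(F)F)cc3)cc2)CCC2(CCNCC2)C1` gives 7220 nM. Compound 2 `CC(=O)Nc1ccc(Oc2ccc(S(=O)(=O)C3(C(=O)Nc4ccccc4N)CCC4(CCNCC4)C3)cc2)cc1` gives > 100000 nM, which is a limit of the assay. Compound 3 `Nc1ccccc1NC(=O)C1(S(=O)(=O)c2ccc(NC3CCCCC3)cc2)CCC2(CCNCC2)C1` differs from compound 2 by cyclohexylamino in place of 4-acetamidophenoxy on an aromatic carbon. Going by the values given here, the one measured step, an at least 13-fold higher number from compound 1 to compound 2 (1.14 log units; beyond the scatter), is large and brought in the acetamido group that compound 3 lacks. A large step to a lower number is therefore expected in this assay. The expected change is an at least 6.6-fold lower number from compound 2 to compound 3 (0.82 log units; beyond the scatter). The estimate for compound 3 is 15000 nM, with an expected range of 4000 nM to 60000 nM.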

Compound 3, concentration lethal to 50% of the cells: 43800 nM
Compound 3: middle estimate off by 2.9-fold (0.47 log units), on the low side; measured number inside the range.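

In this assay, this position still responds when the whole 4-acetamidophenoxy group gives way to cyclohexylamino (an at least 2.2-fold lower number from compound 2 to compound 3 (0.35 log units; beyond the scatter)), yet the same cyclohexylamino group gives a higher number than 4-(trifluoromethoxy)phenoxy (a 6.1-fold higher number from compound 1 to compound 3 (0.78 log units; beyond the scatter)). A higher number than that of compound 1 therefore does not depend on the acetamido group. Going by these compounds, compound 2 stands at a limit, so the true size of its step stays unknown: the limit of > 100000 nM in this assay, at which 1 of the 3 values shown sits.

On these data alone, whether the ring or its nitrogen link matters more remains open. A phenylamino or cyclohexyloxy group here would separate the two.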